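The source may hold more compounds than are shown below. What is called first, only, known or untested is meant among the compounds shown, and "the series" means these compounds.

Measured in a functional assay on K-562R cells (Homo sapiens) for cytotoxicity, read by MTT assay, with a stated time of 48 h; on this read-out higher numbers stand for weaker inhibition and lower numbers for stronger inhibition:
- Compound 1 `COc1ccc(-c2c[nH]c(=O)n2-c2cc(OC)c(OC)c(OC)c2)cc1[N+](=O)[O-]`: > 50000 nM, a limit.
- Compound 2 `COc1ccc(-c2cn(C(C)=O)c(=O)n2-c2cc(OC)c(OC)c(OC)c2)cc1`: 9500 nM.
- Compound 3 `COc1ccc(-c2cn(C(C)=O)c(=O)n2-c2cc(OC)c(OC)c(OC)c2)cc1OC`: > 50000 nM, a limit.

Compound 3 gives no number in this assay and stands at the limit of > 50000 nM in this assay, at which 2 of the 3 values shown sit. Compound 4 `COc1ccc(-c2cn(C(C)=O)c(=O)n2-c2cc(OC)c(OC)c(OC)c2)cc1[N+](=O)[O-]` differs from it by nitro in place of methoxy on an aromatic carbon, ortho to a methoxy group and meta to a large group (nitro in place of methoxy on an aromatic carbon).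

Two measurements bear on this change. The step of an at least 5.2-fold higher number from compound 2 to compound 3 (0.72 log units; beyond the scatter) comes from methoxy in place of hydrogen at that same carbon, so losing this methoxy could allow a lower number. Against this, compound 1, which already carries the nitro but lacks the acetyl group, gives > 50000 nM, again a limit. Among the measured compounds shown here, no measured compound pairs the nitro with the acetyl group, so the direction is only tentatively towards a lower number, with a real chance of staying at the limit.

The expected change is an at least 1.7-fold lower number from compound 3 to compound 4 (0.25 log units; that floor lies within the scatter), a modest one. For compound 4 the estimate is 28000 nM, with an expected range of 8000 nM to 50000 nM.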

Compound 4, half-maximal inhibitory concentration: > 50000 nM
Compound 4 was reported as a limit; the forecaster's own chance of this, stated with the estimate: 50%; middle value at least 1.7-fold (0.25 log units) from the limit.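

In this assay compound 4 gives > 50000 nM, which is a limit. With the acetyl group kept, nitro in place of hydrogen on this aromatic carbon gives an at least 5.2-fold higher number from compound 2 to compound 4 (0.72 log units; beyond the scatter), so nitro, like methoxy in compound 3, loses the readable number that compound 2 shows with hydrogen at this carbon. The steps from compound 3 to compound 4 and from compound 1 to compound 4 join two limits and cannot be read, and compound 1, compound 3 and compound 4 now stand at the same place: the limit of > 50000 nM in this assay, at which 3 of the 4 values shown sit.

Among the compounds shown here, whether hydrogen is the only group at this carbon that keeps a readable number stays open, and a fluorine, a hydroxyl or an amine there, with the acetyl group kept, would test this. On these data alone, how far compound 3 and compound 4 lie beyond the limit, and whether they differ at all, also stays unknown.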